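Trifluoromethyl to Methyl on a Shared Trimethoxyphenyl Core

The source may report more compounds than this note shows. Statements on the series, on what has been measured and on what is new or still open speak of the compounds shown alone.

Of the compounds shown here, three have been measured in a functional assay on MDA-MB-231 cells (Homo sapiens) for inhibition, read by MTT assay, with a stated time of 48 h; on this read-out higher numbers stand for weaker inhibition and lower numbers for stronger inhibition. Compound 1, `COc1cc(-c2nccn3cc(-c4ccc(C(F)(F)F)cc4)nc23)cc(OC)c1OC`, gives > 10000 nM, a limit of the assay. Compound 2, `COc1cc(-c2nccn3cc(-c4ccccc4)nc23)cc(OC)c1OC`, gives 364 nM. Compound 3, `COc1cc(-c2nccn3cc(-c4ccc([N+](=O)[O-])cc4)nc23)cc(OC)c1OC`, gives > 10000 nM, again a limit.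

Compound 1 therefore stands at the weak end of the numbers shown, at the limit of > 10000 nM in this assay, at which 2 of the 3 values shown sit, and only compound 2 gives an actual number. Compound 4, `COc1cc(-c2nccn3cc(-c4ccc(C)cc4)nc23)cc(OC)c1OC`, differs from compound 1 in one place: methyl in place of trifluoromethyl on an aromatic carbon.

Within the data shown here, two steps bear on this change. Removing the trifluoromethyl altogether gave an at least 27-fold lower number from compound 1 to compound 2 (1.43 log units; beyond the scatter), while adding a nitro gave an at least 27-fold higher number from compound 2 to compound 3 (1.43 log units; beyond the scatter); the step that the two limits leave unreadable from compound 1 to compound 3 is not readable. A methyl is smaller than trifluoromethyl yet larger than hydrogen, so compound 4 is expected to fall between compound 1 and compound 2, with an expected step of an at least 3.3-fold lower number from compound 1 to compound 4 (0.52 log units; beyond the scatter), though a further limit cannot be excluded. The estimated value for compound 4 in this assay is 3000 nM, with a range from 500 nM to 10000 nM.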

Compound 4, half-maximal inhibitory concentration: 53 nM
The estimate for compound 4 lay 57-fold (1.75 log units) above the measured number; measured number outside the range, below it.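

On this aromatic carbon a substituent can do better than hydrogen: in this assay, the methyl gives a 6.9-fold lower number from compound 2 to compound 4 (0.84 log units; beyond the scatter), which compounds 1 to 3 had not shown. The loss seen with trifluoromethyl and nitro therefore does not extend to every group at this place, as replacing trifluoromethyl gives an at least 180-fold lower number from compound 1 to compound 4 (2.27 log units; beyond the scatter) and replacing nitro gives an at least 180-fold lower number from compound 3 to compound 4 (2.27 log units; beyond the scatter). Both of these steps start from a limit of the assay rather than a number: the limit of > 10000 nM in this assay, at which 2 of the 4 values shown sit.

The compounds shown leave open whether the gain is particular to methyl or extends to other groups on this carbon, such as an ethyl, a methoxy, a chlorine or an amine. They also cannot tell what separates methyl from trifluoromethyl and nitro, two groups whose compounds give no actual number here.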